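Amide side chain step to compound 3

The compounds below may be only part of what the source reports. "The series", "measured", "known", "first", "only" and "open" are said of these compounds alone.

Values so far in a functional assay on MCF7 cells (Homo sapiens) for antiproliferative activity, read by MTT assay, with a stated time of 24 h; a higher number here means a weaker inhibitor, a lower number a stronger inhibitor
- compound 1 `CCn1c(C(=O)N[C@@H](CO)C(C)C)ccc1C(CC)(CC)c1ccc(OCS(=O)(=O)c2ccccc2)c(C)c1` gives 18800 nM
- compound 2 `CCn1c(C(=O)N[C@@H](C)C(=O)O)ccc1C(CC)(CC)c1ccc(OCS(=O)(=O)c2ccccc2)c(C)c1` gives 35500 nM

Compound 2, at 35500 nM, stands level with compound 1 on these numbers, and neither can be ranked over the other. The unmeasured compound 3 `CCn1c(C(=O)N[C@@H](C(=O)O)C(C)C)ccc1C(CC)(CC)c1ccc(OCS(=O)(=O)c2ccccc2)c(C)c1` differs from compound 2 by one change (1-carboxy-2-methylpropyl in place of 1-carboxyethyl on an amide-type nitrogen), with 1-carboxy-2-methylpropyl in place of 1-carboxyethyl on an amide-type nitrogen. Among the compounds with values here, the one measured step that bears on this is a 1.9-fold higher number from compound 1 to compound 2 (0.28 log units; within the scatter), which replaced 1-(hydroxymethyl)-2-methylpropyl with 1-carboxyethyl on the same amide-type nitrogen. Within the data shown here, that step stayed within the scatter, and it is the only evidence available. Among the measured compounds shown here, no measured pair isolates the change from 1-carboxyethyl to 1-carboxy-2-methylpropyl, so the expectation remains loose. Resting on the small size of that step, no shift beyond the scatter is expected in this assay. The expected step is a 1.3-fold lower number from compound 2 to compound 3 (0.10 log units; within the scatter), which is an estimate only. The estimated value for compound 3 is 28000 nM (expected range 14000 nM to 56000 nM).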

Compound 3, half-maximal inhibitory concentration: 44700 nM
For compound 3 the middle estimate is 1.6-fold (0.20 log units) below the measured one; low and high end bracket the measured number.
By their numbers in this assay, from the lowest: compounds 1, 2 and 3 (each within the scatter of the next, the first and the last beyond it).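

In this assay, 1-carboxy-2-methylpropyl in place of 1-carboxyethyl on the amide-type nitrogen gives a 1.3-fold higher number from compound 2 to compound 3 (0.10 log units; within the scatter), so these two carboxylic acid side chains cannot be told apart on these numbers. Within the data shown here, the comparison of compound 1 with compound 3 is the first to isolate the end group on the 2-methylpropyl-bearing chain: carboxy in place of hydroxymethyl on the saturated chain carbon gives a 2.4-fold higher number from compound 1 to compound 3 (0.38 log units; beyond the scatter), and this is the only step so far that clears the scatter. Nothing available on these compounds accounts for that step.

On these data alone, it remains open whether a methyl ester or a primary amide in place of the carboxy group on that chain carbon would read with compound 1, with compound 3 or apart from both. A 1-(hydroxymethyl)ethyl group on the same nitrogen would show whether the carboxy-for-hydroxymethyl step also holds on the side chain of compound 2, and an amine at that chain carbon would extend the comparison beyond the hydroxymethyl and carboxy end groups.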